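Hydrogen in place of fluoro on the benzylamino group

This account rests on a few compounds, and the source may have more. Where it says the series, first, only, none or still open, it means among the compounds named here.

Measured so far:
compound 1 `O=C(c1nn(-c2ccccc2)c2c1CC(NCc1ccccc1)CC2)N1CCCCC1`: 631 nM
compound 2 `O=C(c1c2c(nn1-c1ccccc1)CCC(NCc1ccc(F)cc1)C2)N1CCCCC1`: 31.6 nM

Of the compounds shown here, two have been measured in an assay on HEK293 cells for displacement of a labelled ligand from Sigma non-opioid intracellular receptor 1 (Homo sapiens), read by scintillation counting, with a stated time of 120 min; a lower number here means a stronger inhibitor, a higher number a weaker inhibitor. Compound 1 `O=C(c1nn(-c2ccccc2)c2c1CC(NCc1ccccc1)CC2)N1CCCCC1` gives 631 nM, while compound 2 `O=C(c1c2c(nn1-c1ccccc1)CCC(NCc1ccc(F)cc1)C2)N1CCCCC1` gives 31.6 nM. Compound 2 thus stands at the lower of the two numbers, and its gap to compound 1 lies beyond the scatter of this assay. Compound 1 also carries a benzylamino group without fluorine, but it differs from compound 2 in more than that one place, so its value is no guide to the fluorine on its own.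

Compound 3 `O=C(c1c2c(nn1-c1ccccc1)CCC(NCc1ccccc1)C2)N1CCCCC1` differs from compound 2 in a single place: hydrogen in place of fluoro on an aromatic carbon. Among the measured compounds shown here, no step between measured compounds that differ in one place has been recorded, so the expectation rests on the structural change alone. A change of this kind is expected to move the number only modestly, most likely upward, close to the edge of the scatter. Compound 3 is therefore expected to give 80 nM, within a range of 25 nM to 320 nM. The expected step of a 2.5-fold higher number from compound 2 to compound 3 (0.40 log units; beyond the scatter) is estimated as a small loss in this assay.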

Compound 3, inhibition constant: 39.8 nM
For compound 3 the middle estimate is 2.0-fold (0.30 log units) above the measured one; measured number inside the range.
By their numbers in this assay, from the lowest: compounds 2 and 3 (each within the scatter of the next); then compound 1.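

In this assay, the step on replacing fluoro with hydrogen on an aromatic carbon is a 1.3-fold higher number from compound 2 to compound 3 (0.10 log units; within the scatter) and therefore gives no ground for placing one of these two compounds ahead of the other. Among the compounds shown here, this is the first comparison in which only one place differs, and it isolates the fluorine in a way that the earlier pair could not: with an unsubstituted benzylamino group, compound 3 gives 39.8 nM in this assay, so a value of this size does not depend on the 4-fluorobenzyl group. No independent measurement is available to explain this result, and the comparison shows only the size of the step for this one exchange on the shared core.

The compounds shown leave open whether this tolerance extends beyond hydrogen and fluoro at this place, for example to chloro, methoxy, an amine or a carboxylic acid on the aromatic ring. They also leave open whether a longer chain between the nitrogen and the phenyl ring would give a value in the same range, with or without the fluorine.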